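Carrying a 4-Methoxyphenyl Group onto the Amide Nitrogen

A few compounds are considered here, and "the series" means these few. Any claim that something is new, unique, unknown or untested is made for them only; others in the source may bear on it.

Measured compounds in an ADME assay on Vero cells (Chlorocebus sabaeus) for cytotoxicity; a higher number here means that more compound is tolerated, a lower number that less compound is tolerated:
Compound 1 `CCN(CC)CN1C(=O)/C(=N/NC(N)=S)c2ccccc21` gives > 100000 nM, which is a limit of the assay and not a number.
Compound 2 `CCN(CC)CN1C(=O)/C(=N/NC(=S)Nc2ccc(Cl)cc2)c2cc(Cl)ccc21` gives 100000 nM.
Compound 3 `CCN(CC)CN1C(=O)/C(=N/NC(=S)Nc2ccc(C)cc2)c2cc(Cl)ccc21` gives >= 4000 nM, again a limit of the assay rather than a number.

Compound 1 therefore stands at the tolerant end of this assay, with only a limit to show; of the three values, one further one is also a limit. Going by the values given here, the single step between measured compounds that differ in one place, a step that the limit leaves unreadable from compound 2 to compound 3, is methyl in place of chloro on an aromatic carbon, and its size cannot be read because compound 3 sits at the limit of >= 4000 nM in this assay, at which 1 of the 3 values shown sits.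

Compound 4 `CCN(CC)CN1C(=O)/C(=N/NC(=S)Nc2ccc(OC)cc2)c2ccccc21` has not yet been measured. Against compound 1 it shows (4-methoxyphenyl in place of hydrogen on an amide-type nitrogen). Among the compounds with values here, no measured step bears directly on this change. Compound 2 and compound 3 do carry an aryl group on that nitrogen, but both also differ from compound 1 in a chloro on the shared core, so their values can only hint that such compounds stay well tolerated. The step expected here is an at least 1.2-fold lower number from compound 1 to compound 4 (0.09 log units; that floor lies within the scatter), not beyond the scatter. Compound 4 is thus expected near 80000 nM, in a range from 20000 nM to 200000 nM.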

Compound 4, minimum cytotoxic concentration: 4000 nM
For compound 4 the middle estimate is 20-fold (1.30 log units) above the measured one, and the stated range ends above it.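

Going by these compounds alone, this is the first direct reading of what a substituent on this nitrogen does to the otherwise unchanged core: in this assay, 4-methoxyphenyl in place of hydrogen on the amide-type nitrogen gives an at least 25-fold lower number from compound 1 to compound 4 (1.39 log units; beyond the scatter). Compound 2 and compound 3 also carry an aryl group on that nitrogen, but each differs from compound 1 in a chloro on the shared core as well, so neither isolates this change, and the position now proves to be far from neutral for tolerance in these cells. The true size of the step could be larger than printed, because the value for compound 1 is a limit of the assay and not a number: the limit of > 100000 nM in this assay, at which 1 of the 4 values shown sits.

The compounds shown leave open whether the lower number goes with the phenyl ring itself or with the methoxy group it carries, a question that a plain phenyl or a 4-hydroxyphenyl on the same nitrogen would address. Also open, from the compounds shown here alone, is whether a short chain such as ethyl at this position, or an amine or a carboxylic acid in place of the methoxy group, would bring tolerance back toward that of compound 1.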